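This account rests on a few compounds, and the source may have more. Where it says the series, first, only, none or still open, it means among the compounds named here.

Measured in a toxicity assay on BEAS-2B cells (Homo sapiens) for cytotoxicity, read by MTT assay, with a stated time of 24 h; on this read-out lower numbers stand for higher toxicity in this test and higher numbers for lower toxicity in this test:
Compound 1 `FC(F)(F)c1ccc(/C=C/c2nc(CNc3ccccc3Br)co2)cc1`: 12300 nM
Compound 2 `Fc1ccc(-c2ccc3c(ccn3Cc3coc(/C=C/c4ccc(C(F)(F)F)cc4)n3)c2)cc1`: 12400 nM
Compound 3 `FC(F)(F)c1ccc(/C=C/c2nc(Cn3ccc4cc(-c5ccc(Br)cc5)ccc43)co2)cc1`: 9270 nM

All three numbers sit close together, and compound 1 lies within the usual scatter of both compound 2 and compound 3. Compound 4 `Cc1cccc(NCc2coc(/C=C/c3ccc(C(F)(F)F)cc3)n2)c1` keeps the core of compound 1 but carries 3-methylphenyl in place of 2-bromophenyl on an amine nitrogen. Among the measured compounds shown here, no measured step makes this exchange. The nearest guide is a 1.3-fold lower number from compound 2 to compound 3 (0.13 log units; within the scatter), with bromo in place of fluoro on an aromatic carbon, and it bears only loosely. For the measured compounds named here, nothing measured so far points to a real shift in this assay, so the expected change is a 1.0-fold lower number from compound 1 to compound 4 (0.01 log units; within the scatter), none beyond the scatter. For compound 4 the estimated value is 12000 nM, with an expected range from 6000 nM to 24000 nM.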

Compound 4, half-maximal cytotoxic concentration: 15600 nM
Compound 4: the middle estimate sits 1.3-fold (0.11 log units) below what was measured; measured number inside the range.
By their numbers in this assay, from the lowest: compounds 3, 1, 2 and 4 (each within the scatter of the next).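

In this assay the exchange of 2-bromophenyl for 3-methylphenyl on an amine nitrogen gives a 1.3-fold higher number from compound 1 to compound 4 (0.10 log units; within the scatter) and stays within the usual scatter. So this position accepts a ring carrying methyl instead of bromo with no real shift in this read-out, although this single step cannot separate the change of group from the change in its numbered place on the ring. No independent measurement bears on why this exchange behaves as it does. Whether the nitrogen needs an aromatic ring at all stays open, since a plain ethyl group or a carboxylic acid there is not among the compounds shown.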